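This account rests on a few compounds, and the source may have more. Where it says the series, first, only, none or still open, it means among the compounds named here.

Measured so far in a physicochemical assay for lipophilicity, measured as octanol-water partition, at pH 7.4; a higher number here means a more lipophilic compound, a lower number a more polar compound:
- compound 1 `Cc1ccc2[nH]c(C(=O)N[C@H]3CN(S(=O)(=O)c4cnccn4)C[C@@H]3C(=O)NCCN(C)C)cc2c1`: 1
- compound 2 `Cc1ccc2[nH]c(C(=O)N[C@H]3CN(S(=O)(=O)c4cn(C)nc4C)C[C@@H]3C(=O)NCCN(C)C)cc2c1`: 1.4
- compound 3 `Cc1ccc2[nH]c(C(=O)N[C@H]3CN(S(=O)(=O)c4ccccc4)C[C@@H]3C(=O)NC[C@@H]3CCCN3C)cc2c1`: 2.3

Compound 3, at 2.3, has the highest number of the three, and its gaps to compound 2 and compound 1 both lie beyond the scatter. Compound 4 `Cc1ccc2[nH]c(C(=O)N[C@H]3CN(S(=O)(=O)c4ccccc4)C[C@@H]3C(=O)N[C@H]3CCCNC3)cc2c1` has not yet been measured. It differs from compound 3 in one place, with piperidin-3-yl in place of (1-methylpyrrolidin-2-yl)methyl on an amide-type nitrogen.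

Going by the values given here, the only single-place comparison available is a number 0.40 log units higher from compound 1 to compound 2 (beyond the scatter). That change lies on a sulfonyl sulfur, so it bears on the present change only as a rough guide to size. Among the compounds with values here, no measured pair isolates a change on the amide-type nitrogen. The entering group does carry a hydrogen-bond donor, which the leaving group lacks, so a modest fall in this assay is expected, though with little direct support. The estimated step is a number 0.50 log units lower from compound 3 to compound 4 (beyond the scatter). For compound 4 the expected value is 1.8, with an estimated range from 1.2 to 2.4.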

Compound 4, distribution coefficient: 1.3
For compound 4 the middle estimate is 0.50 log units above the measured one; measured number inside the range.
By their numbers in this assay, from the lowest: compounds 1, 4 and 2 (each within the scatter of the next, the first and the last beyond it); then compound 3.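

In this assay, going by these compounds alone, piperidin-3-yl in place of (1-methylpyrrolidin-2-yl)methyl on an amide-type nitrogen gives a number 1.00 log units lower from compound 3 to compound 4 (beyond the scatter) and is the first single-place step read at this position. Within the data shown here, its size exceeds that of the only earlier step, on a sulfonyl sulfur, which was a number 0.40 log units higher from compound 1 to compound 2 (beyond the scatter) in a different setting, so the amide-type nitrogen can move this read-out substantially. No measurement at hand accounts for the size of the step.

The change alters the ring size, the ring-nitrogen substituent and the hydrogen-bond donor count together, so the compounds shown leave open which of these differences matters; a 1-methylpiperidin-3-yl or a pyrrolidin-2-ylmethyl group would help to separate them. On these data alone, it also remains open whether the step would be the same with pyrazin-2-yl or 1,3-dimethyl-1H-pyrazol-4-yl on the sulfonyl sulfur.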